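A fluorine for the hydroxy of compound 1

The source may report more compounds than this note shows. Statements on the series, on what has been measured and on what is new or still open speak of the compounds shown alone.

The shared core carries two aromatic rings on one saturated chain carbon, and the chain beyond that carbon is where the three measured compounds differ. Compound 1 `COc1cc(C(c2ccc(O)c(OC)c2)[C@H](C)[C@H](C)CO)ccc1O` reaches only a limit in a functional assay on HL-60 cells (Homo sapiens) for cytotoxicity, read by WST assay, with a stated time of 48 h (a higher number here means a weaker inhibitor, a lower number a stronger inhibitor), namely > 100000 nM. Compound 3 `COc1cc(C(c2ccc(O)c(OC)c2)[C@H](C)[C@@H](C)CO)ccc1O` differs from compound 1 only in the configuration as drawn; in this assay compound 3 also sits at a limit, > 100000 nM. The pair gives a step that the two limits leave unreadable from compound 1 to compound 3, a step that stays unreadable because of the limit of > 100000 nM in this assay, at which 2 of the 3 values shown sit. Among the compounds with values here, compound 2 `COc1cc(C(c2ccc(O)c(OC)c2)[C@H](CF)C(C)C)ccc1O` is the one compound with a number, 19000 nM, so that an at least 5.2-fold lower number from compound 1 to compound 2 (0.72 log units; beyond the scatter) and an at least 5.2-fold higher number from compound 2 to compound 3 (0.72 log units; beyond the scatter) are the two readable steps, and both bring a fluoromethyl into the chain where a hydroxymethyl left, though in a different arrangement of the chain.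

Compound 4 `COc1cc(C(c2ccc(O)c(OC)c2)[C@H](C)[C@H](C)CF)ccc1O` is not yet measured. It differs from compound 1 by fluoro in place of hydroxy on a saturated chain carbon, four bonds along the chain from two aromatic carbons. Within the data shown here, the only guide is the step to compound 2, which carried the same exchange of a hydroxy for a fluoro together with a rearranged chain and moved the number out of the limit. The same direction is expected here, at a size of an at least 2.5-fold lower number from compound 1 to compound 4 (0.39 log units; beyond the scatter), though part of the earlier step may belong to the rearranged chain. Compound 4 is therefore estimated at 40000 nM in this assay, within 12000 nM to 150000 nM, with a real chance that only a limit is reported again.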

Compound 4, half-maximal inhibitory concentration: 56000 nM
Estimate against measurement, compound 4: 1.4-fold (0.15 log units) below; measured number inside the range.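

Compound 4 carries the exchange of hydroxy for fluoro on a saturated chain carbon, four bonds along the chain from two aromatic carbons, with no rearrangement of the chain, and in this assay this change alone gives an at least 1.7-fold lower number from compound 1 to compound 4 (0.25 log units; that floor lies within the scatter). The exchange of 1-(hydroxymethyl)ethyl for 1-(fluoromethyl)ethyl gives an at least 1.7-fold lower number from compound 3 to compound 4 (0.25 log units; that floor lies within the scatter), so neither floor by itself shows a change beyond the scatter, and both steps start from a limit rather than a number: the limit of > 100000 nM in this assay, at which 2 of the 4 values shown sit. Between the two fluorinated chains, 2-(fluoromethyl)-1-methylpropyl in place of 1-(fluoromethyl)-2-methylpropyl gives a 2.9-fold higher number from compound 2 to compound 4 (0.47 log units; beyond the scatter), which shows that the arrangement of the chain alone moves the number once fluoro is present.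

A methyl, a methoxy or an amine at the same chain end would show whether the loss of the hydroxy or the entry of the fluoro carries the step. The role of configuration also stays open, as the step between the two hydroxy compounds cannot be read, and the compounds shown include no fluoromethyl pair that differs only in configuration.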